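Compound 4: an aryl change starting from a limit

A few compounds are considered here, and "the series" means these few. Any claim that something is new, unique, unknown or untested is made for them only; others in the source may bear on it.

Measured in an ADME assay on HEp-2 cells (Homo sapiens) for cytotoxicity, read by MTT assay, with a stated time of 72 h; on this read-out higher numbers stand for weaker inhibition and lower numbers for stronger inhibition:
Compound 1 `COc1ccc(C2=C(c3cc(OC)c(OC)c(OC)c3)C(=O)CC2O[SiH2]C(C)(C)C)cc1` gives > 100 ug/mL
Compound 2 `C=CCOc1cc(C2=C(c3cc(OC)c(OC)c(OC)c3)C(=O)C(O)C2)ccc1OC` gives > 100 ug/mL
Compound 3 `COc1ccc(C2=C(c3cc(OC)c(OC)c(OC)c3)C(=O)C(O)C2)cc1` gives < 1 ug/mL

Compound 1 stands at > 100 ug/mL, which is a limit of this assay and not a number. It therefore sits at the limit of > 100 ug/mL in this assay, at which 2 of the 3 values shown sit. Compound 3 gives < 1 ug/mL, which is also a limit.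

Compound 4 `COc1ccc(OC)c(C2=C(c3cc(OC)c(OC)c(OC)c3)C(=O)CC2O[SiH2]C(C)(C)C)c1` keeps the core of compound 1 and differs from it in one place: 2,5-dimethoxyphenyl in place of 4-methoxyphenyl on a double-bonded ring carbon.

Among the measured compounds shown here, one measured step bears on this change, since it also alters an aryl group on the shared core: an at least 100-fold lower number from compound 2 to compound 3 (2.00 log units; beyond the scatter). That step is large, so a change on this aromatic ring can matter a great deal. Its direction, however, goes with a group leaving, whereas in compound 4 the larger 2,5-dimethoxyphenyl enters. For the measured compounds named here, the data hold no step in which a group entering on this ring gives a lower number, so a lower number is not expected here. Compound 4 is therefore expected to stay near the upper limit, with no step beyond the scatter. The step expected is a number no higher from compound 1 to compound 4 (the limit leaves the size open). The estimate for compound 4 is 100 ug/mL, with an expected range from 40 ug/mL to 250 ug/mL.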

Compound 4, half-maximal inhibitory concentration: 19 ug/mL
For compound 4 the middle estimate is 5.3-fold (0.72 log units) above the measured one; measured number outside the range, below it.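

In this assay, 2,5-dimethoxyphenyl in place of 4-methoxyphenyl on a double-bonded ring carbon gives an at least 5.2-fold lower number from compound 1 to compound 4 (0.72 log units; beyond the scatter), so a group entering on this aromatic ring can lower the number, which no earlier step had shown. Among the compounds shown here, the only earlier step on an aryl group, an at least 100-fold lower number from compound 2 to compound 3 (2.00 log units; beyond the scatter), came with a group leaving, so the compounds now show lower numbers from changes in both directions, though on two different forms of the shared core. Compound 1 gives > 100 ug/mL, which is a limit and not a number, and the new step is read from it: the limit of > 100 ug/mL in this assay, at which 2 of the 4 values shown sit.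

The compounds shown leave open which part of 2,5-dimethoxyphenyl goes with the lower number, and whether this aryl group would give a similar step on the core of compound 3. They also do not tell how an amine or a carboxylic acid on this aromatic ring, in place of a methoxy group, would read in this assay.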